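Methoxy in place of methyl on compound 1

The source may report more compounds than this note shows. Statements on the series, on what has been measured and on what is new or still open speak of the compounds shown alone.

Compound 1 `Cc1ccc(N2CCCC2)c(C(=O)Nc2ccc(CNC(=O)OCc3cccnc3)cc2)c1`: 65300 nM
Compound 2 `O=C(NCc1ccc(NC(=O)c2ccc(F)cc2N2CCCC2)cc1)OCc1cccnc1`: 56200 nM

Both values come from a functional assay on SGC-7901 cells (Homo sapiens) for inhibition, read by MTT assay, with a stated time of 72 h (a lower number here means a stronger inhibitor, a higher number a weaker inhibitor), and they lie within the scatter of each other, so compound 1 stands level with compound 2. Compound 3 `COc1ccc(N2CCCC2)c(C(=O)Nc2ccc(CNC(=O)OCc3cccnc3)cc2)c1` has methoxy in place of methyl on an aromatic carbon. Among the measured compounds shown here, no measured pair shows this change. In this assay no step beyond the scatter is expected, in either direction. The estimate amounts to an expected step of a 1.3-fold lower number from compound 1 to compound 3 (0.12 log units; within the scatter). Compound 3 is expected at 50000 nM. The estimated range for compound 3 runs from 20000 nM to 100000 nM.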

Compound 3, half-maximal inhibitory concentration: 47200 nM
Compound 3: the middle estimate sits 1.1-fold (0.03 log units) above what was measured; measured number inside the range.
By their numbers in this assay, from the lowest: compounds 3, 2 and 1 (each within the scatter of the next).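

Methoxy in place of methyl on the aromatic carbon para to a pyrrolidin-1-yl group gives a 1.4-fold lower number from compound 1 to compound 3 (0.14 log units; within the scatter) in this assay. Among the compounds shown here, compound 1 and compound 2 offered no one-place step, so this is the only reading of this position so far, and the swap leaves compound 3 level with compound 1. No measurement bears on why the number holds here.

As far as these compounds go, whether an amine, a carboxylic acid or a longer chain such as butoxy at this position would give a step beyond the scatter stays open.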